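Replacing fluoro with ethoxy on the shared core

The compounds below may be only part of what the source reports. "The series", "measured", "known", "first", "only" and "open" are said of these compounds alone.

In an ADME assay on L6 cells (Rattus norvegicus) for cytotoxicity (on this read-out lower numbers stand for stronger inhibition and higher numbers for weaker inhibition), compound 1 `O=C(NN(Cc1ccccc1)Cc1ccccc1)c1cc([N+](=O)[O-])ccc1F` gives 19300 nM, compound 2 `O=C(NN(c1ccccc1)c1ccccc1)c1cc([N+](=O)[O-])ccc1Cl` gives 13300 nM and compound 3 `O=C(NN(c1ccccc1)c1ccccc1)c1cc([N+](=O)[O-])ccc1F` gives 3200 nM, the lowest of the three numbers. Compound 4 `CCOc1ccc([N+](=O)[O-])cc1C(=O)NN(c1ccccc1)c1ccccc1` differs from compound 3 by ethoxy in place of fluoro on an aromatic carbon. For the measured compounds named here, the only measured change at this place is a 4.2-fold lower number from compound 2 to compound 3 (0.62 log units; beyond the scatter), a modest step beyond the scatter, and no ethoxy compound has a number yet. Read in reverse, that step suggests that leaving fluoro goes with a higher number, so a modest rise in this assay is expected. The estimated change is a 2.8-fold higher number from compound 3 to compound 4 (0.45 log units; beyond the scatter). For compound 4 the expected value is 9000 nM, with an estimated range of 3500 nM to 22000 nM.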

Compound 4, half-maximal inhibitory concentration: 185000 nM
Compound 4: the middle estimate sits 21-fold (1.31 log units) below what was measured, outside the stated range (above it).
By their numbers in this assay, from the lowest: compound 3; then compounds 2 and 1 (each within the scatter of the next); then compound 4.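

On this position of the shared core, the swap between halogens moves the number only modestly in this assay, but ethoxy brings a 58-fold higher number from compound 3 to compound 4 (1.76 log units; beyond the scatter) and a 14-fold higher number from compound 2 to compound 4 (1.14 log units; beyond the scatter). The position is therefore far more sensitive to this change than the chloro and fluoro pair alone suggested, with compound 4 well above both halogen compounds. Nothing at hand accounts for the size of this step.

Going by these compounds, whether the rise follows the ring-bound oxygen or the chain remains open, and a methoxy group or an amine here would help separate the two. On these data alone, whether ethoxy has the same effect on the core of compound 1 is also open.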